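A piperidine swap on the propoxy chain of compound 1

The compounds below may be only part of what the source reports. "The series", "measured", "known", "first", "only" and "open" are said of these compounds alone.

compound 1, `COc1cc2c(Nc3ccc(C#N)cc3)ncnc2cc1OCCCN(C)Cc1ccccc1`: > 100000 nM
compound 2, `COc1cc2c(Nc3ccc(C#N)cc3)ncnc2cc1OCCCN1CCC(C)CC1`: 7900 nM

Of the compounds shown here, two have so far been measured in a functional assay on SH-SY5Y cells (Homo sapiens) for antiproliferative activity, read by MTT assay, with a stated time of 72 h; on this read-out lower numbers stand for stronger inhibition and higher numbers for weaker inhibition. For compound 1 the reported value > 100000 nM is a limit of the assay, not a number. Compound 2 gives 7900 nM in this assay. Among the measured compounds shown here, the single measured step, an at least 12-fold lower number from compound 1 to compound 2 (1.10 log units; beyond the scatter), comes from 4-methylpiperidin-1-yl in place of benzyl(methyl)amino on a saturated chain carbon, three bonds along the chain from an oxygen on an aromatic ring; its true size is open because compound 1 sits at the limit of > 100000 nM in this assay, at which 1 of the 2 values shown sits.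

Compound 3, `COc1cc2c(Nc3ccc(C#N)cc3)ncnc2cc1OCCCN1CCC(N(C)C)CC1`, differs from compound 1 by 4-(dimethylamino)piperidin-1-yl in place of benzyl(methyl)amino on a saturated chain carbon, three bonds along the chain from an oxygen on an aromatic ring. As in the measured step, a piperidin-1-yl ring replaces benzyl(methyl)amino at the same place, so a large step toward lower numbers is expected, of a size close to that seen for compound 2. Compound 3 is therefore expected to give 7000 nM in this assay, within a range from 2000 nM to 30000 nM. That expectation amounts to an at least 14-fold lower number from compound 1 to compound 3 (1.15 log units; beyond the scatter).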

Compound 3, half-maximal inhibitory concentration: 24300 nM
Compound 3: middle estimate off by 3.5-fold (0.54 log units), on the low side; low and high end bracket the measured number.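

In this assay, a second piperidin-1-yl ring at this place on the chain also replaces benzyl(methyl)amino with a lower number, an at least 4.1-fold lower number from compound 1 to compound 3 (0.61 log units; beyond the scatter), so the drop is not unique to the 4-methylpiperidin-1-yl group. As far as these compounds go, the true size of that step remains open, since the value for compound 1 is only a limit: the limit of > 100000 nM in this assay, at which 1 of the 3 values shown sits. The group on the ring also matters, as dimethylamino in place of methyl on a saturated ring carbon gives a 3.1-fold higher number from compound 2 to compound 3 (0.49 log units; beyond the scatter).

The compounds shown leave open how an unsubstituted piperidine, a morpholine or a piperazine would compare at this place on the chain. They also leave open whether a longer chain would preserve the lower numbers seen with the piperidin-1-yl rings.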